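The compounds below may be only part of what the source reports. "The series", "measured", "known", "first", "only" and "open" are said of these compounds alone.

Compound 1 `Nc1scc(CN2CCN(c3ccncc3)CC2)c1C(=O)c1ccc(Cl)cc1`: in an assay on CHO cells for displacement of a labelled ligand from adenosine receptor A3 (Homo sapiens), read by scintillation counting, with a stated time of 120 min, tested at 10 uM (a higher number here means more inhibition at the concentration tested (going by the name of the read-out), a lower number less inhibition), compound 1 gives 2%.
Compound 2 `Nc1scc(CN2CCN(c3ccc(F)cc3F)CC2)c1C(=O)c1ccc(Cl)cc1`: in this assay compound 2 gives 0%.
Compound 3 `Nc1scc(CN2CCN(c3cccc(F)c3F)CC2)c1C(=O)c1ccc(Cl)cc1`: in this assay compound 3 gives 0%.

All three share one core and differ only in the aromatic group on an amine nitrogen in a ring. Compound 3 reads the same at the digits shown as compound 2, with no change at the digits printed from compound 2 to compound 3 (within the scatter), and compared with compound 1 it shows a number 2 percentage points lower from compound 1 to compound 3 (within the scatter). Since every one of these numbers sits within the usual scatter of the others, none of the three can be separated; each shows essentially no displacement at the concentration tested.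

Compound 4 `Nc1scc(CN2CCN(c3cc(F)ccc3F)CC2)c1C(=O)c1ccc(Cl)cc1` is the next member. Its change from compound 3 is 2,5-difluorophenyl in place of 2,3-difluorophenyl on an amine nitrogen in a ring. Going by the values given here, the step that bears most directly on it is the one from compound 2 to compound 3, where a move of one fluorine around the same ring gave no change at the digits printed from compound 2 to compound 3 (within the scatter); the steps of a number 2 percentage points lower from compound 1 to compound 2 (within the scatter) and a number 2 percentage points lower from compound 1 to compound 3 (within the scatter) likewise stayed flat. No shown step suggests that rearranging two fluorines on this ring moves the read-out, so for compound 4 a step of no change at the digits printed from compound 3 to compound 4 (within the scatter) is expected, that is, nothing beyond the scatter. Compound 4 is therefore estimated at 0%, with a range of -6% to 8%.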

Compound 4, a percentage reported as inhibition, at one concentration (the size of the read-out at that concentration, not a potency): 2%
Compound 4: middle estimate off by 2 percentage points, on the low side, and the stated range covers the measured number.
By their numbers in this assay, from the lowest: compounds 2, 3, 1 and 4 (each within the scatter of the next).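

Placing the 2,5-difluorophenyl group on the amine nitrogen in the ring extends the flat picture in this assay to a third fluorine arrangement: the read-out shows a number 2 percentage points higher from compound 3 to compound 4 (within the scatter) and a number 2 percentage points higher from compound 2 to compound 4 (within the scatter) when the fluorines are rearranged. Comparison with the pyridin-4-yl group gives no change at the digits printed from compound 1 to compound 4 (within the scatter) as well, so this aromatic ring of carbon only and the nitrogen-containing ring cannot be told apart here, and all four compounds remain close to no displacement at the concentration tested. Nothing available accounts for this flatness or shows whether these groups have any real influence on the read-out.

With every number this close to zero, the compounds shown give no starting point for saying what would increase displacement, so they leave open whether a methoxy group or a carboxylic acid on this aromatic ring, or a benzyl group on the same amine nitrogen, would change the result. Also open, going by these compounds, is whether replacing the chlorine on the other aromatic ring with an amine or a longer chain would do so while this position stays unchanged.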